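A few compounds are considered here, and "the series" means these few. Any claim that something is new, unique, unknown or untested is made for them only; others in the source may bear on it.

Working notes on a small set of triazole-linked biaryls. Compound 1 `COc1cccc(-c2ncnn2-c2cc(OC)c(OC)c(OC)c2)c1`, compound 2 `COc1cc(-c2ncnn2-c2ccccc2)cc(OC)c1OC` and compound 3 `COc1cc(-n2ncnc2-c2ccccc2)cc(OC)c1OC` have been run in a functional assay on K562 cells (Homo sapiens) for antiproliferative activity, read by MTT assay, with a stated time of 72 h; a lower number here means a stronger inhibitor, a higher number a weaker inhibitor. In this assay compound 1 gives > 10000 nM, which is a limit of the assay and not a number. In this assay compound 2 gives > 10000 nM, again a limit. In this assay compound 3 gives > 10000 nM, also a limit. Compound 3 and compound 2 share the same atoms joined differently; the difference between the two cores is not broken down here. The change methoxy in place of hydrogen on an aromatic carbon gives a step that the two limits leave unreadable from compound 3 to compound 1, unreadable because of the limit of > 10000 nM in this assay, at which 3 of the 3 values shown sit. Compound 4 `COc1ccc(-n2ncnc2-c2cc(OC)c(OC)c(OC)c2)cc1`, not yet measured, carries the same kind of change, (methoxy in place of hydrogen on an aromatic carbon), the methoxy here para to a large group where in compound 1 it stands meta to a large group. With all three known values sitting at the limit, the step from compound 2 to compound 4 is expected to be a step that the limit leaves unreadable from compound 2 to compound 4. Compound 4 is thus estimated at 20000 nM (range 5000 nM to 100000 nM) in this assay.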

Compound 4, half-maximal inhibitory concentration: 3600 nM
The estimate for compound 4 lay 5.6-fold (0.74 log units) above the measured number; the whole stated range lies above it.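

In this assay, the change from phenyl to 4-methoxyphenyl gives an at least 2.7-fold lower number from compound 2 to compound 4 (0.44 log units; beyond the scatter). On these data alone, compound 2 stands at a limit of the assay and not at a number, so this step has a bound on one side only and its true size stays unknown. The same change cannot be read from compound 3 to compound 1, so carrying it from one core to another is not shown, and the single readable step sets no pattern for the series, because both of that pair sit at the limit: the limit of > 10000 nM in this assay, at which 3 of the 4 values shown sit.

Open, as far as these compounds go, is whether another group in the same place, such as ethoxy, hydroxy or an amine, would also give a lower number. Also open, from the compounds shown here alone, is how methoxy would read on other carbons of that ring.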